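Notes on a benzoyl analogue in a two-compound series

The compounds below may be only part of what the source reports. "The series", "measured", "known", "first", "only" and "open" are said of these compounds alone.

Measured so far:
- compound 1, `COc1ccc(-c2nnc(SCC(=O)c3ccccc3)n2-c2ccccc2)cc1OC`: 59% in a functional assay on the whole organism (strain albino) for inhibition, with Rattus norvegicus as the target, read by paw edema, with a stated time of 3 h, at a dose of 0.28 mmol/kg by the oral route; on this read-out lower numbers stand for less inhibition and higher numbers for more inhibition at the one dose given (going by the name of the read-out)
- compound 2, `O/N=C(/CSc1nnc(-c2ccccc2)n1-c1ccccc1)c1ccccc1`: 65% in this assay

Compound 2 gives the higher of the two numbers, but its nearest neighbour, compound 1, lies within the scatter of it, so no order between the two can be claimed. Both share a core, and neither pair is a single-point step, so what the two values show is only that both sit in the same band.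

Compound 3, `O=C(CSc1nnc(-c2ccccc2)n1-c1ccccc1)c1ccccc1`, is the next compound to be measured in this assay. It differs from compound 2 in one place: a group of 8 heavy atoms (7 carbon, 1 oxygen; one six-membered aromatic ring of carbon only) in place of a group of 9 heavy atoms (7 carbon, 1 nitrogen, 1 oxygen; one six-membered aromatic ring of carbon only), on a saturated chain carbon bound to a sulfur. Compound 1 also carries the benzoyl group on the saturated chain carbon bound to a sulfur and gives 59%, a number within the scatter of compound 2.

For the measured compounds named here, no step between measured compounds is available, so the expected step from compound 2 to compound 3 in this assay is a number 5 percentage points lower from compound 2 to compound 3 (within the scatter), judged as none beyond the scatter. On that basis compound 3 is estimated at 60%, with a range from 48% to 70%.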

Compound 3, a percentage reported as inhibition, in the whole organism at one dose (the size of the read-out at that dose, not a potency): 64%
Compound 3: middle estimate off by 4 percentage points, on the low side; measured number inside the range.
By their numbers in this assay, from the lowest: compounds 1, 3 and 2 (each within the scatter of the next).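

In this assay, benzoyl in place of the group of 9 heavy atoms, on a saturated chain carbon bound to a sulfur, gives a number 1 percentage points lower from compound 2 to compound 3 (within the scatter), so this exchange, which takes the count from 1 hydrogen-bond donor to 0 hydrogen-bond donors, does not separate the two compounds on this read-out. Phenyl in place of 3,4-dimethoxyphenyl on an aromatic carbon gives a number 5 percentage points higher from compound 1 to compound 3 (within the scatter), so the second place in the series, readable for the first time as a single change, also shows no separation at this one dose. No measured evidence on the reason for either result is at hand.

Still open, as far as these compounds go, is whether an amine or a carboxylic acid in place of benzoyl on that saturated chain carbon, or a longer chain carrying the benzoyl group, would stay in the same band. Also open is whether a chlorophenyl group in place of phenyl on the aromatic carbon would move the number beyond the scatter, and how any of these compounds would compare across a range of doses.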